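A few compounds are considered here, and "the series" means these few. Any claim that something is new, unique, unknown or untested is made for them only; others in the source may bear on it.

Measured so far in a functional assay on MCF7 cells (Homo sapiens) for cytotoxicity, read by MTT assay, with a stated time of 72 h; on this read-out higher numbers stand for weaker inhibition and lower numbers for stronger inhibition
compound 1 `O=c1ccc2nc(-c3ccccc3)nn(-c3ccccc3)c-2c1` gives 810 nM
compound 2 `CNc1cc2nc(-c3ccccc3)nn(-c3ccccc3)c-2cc1=O` gives 690 nM
compound 3 `CCNc1cc2nc(-c3ccccc3)nn(-c3ccccc3)c-2cc1=O` gives 1620 nM

Compound 3 at 1620 nM lies within the scatter of compound 1 and apart from compound 2 only modestly. The next compound is compound 4 `CCN(CC)c1cc2nc(-c3ccccc3)nn(-c3ccccc3)c-2cc1=O` with the change ethyl in place of hydrogen on a nitrogen on an aromatic ring and so ethyl in place of hydrogen on a nitrogen on an aromatic ring, ethylamino to diethylamino. Among the measured compounds shown here, no measured step makes this exact replacement. For the measured compounds named here, the nearest precedent is a 2.3-fold higher number from compound 2 to compound 3 (0.37 log units; beyond the scatter) for methyl in place of hydrogen on a saturated chain carbon bound to a nitrogen on an aromatic ring. Two further steps, a 1.2-fold lower number from compound 1 to compound 2 (0.07 log units; within the scatter) and a 2.0-fold higher number from compound 1 to compound 3 (0.30 log units; within the scatter), stay within the scatter and give little direction. A single modest step is thin support, so in this assay only a small upward move is expected, and no change beyond the scatter remains quite possible. The expected step is a 1.2-fold higher number from compound 3 to compound 4 (0.09 log units; within the scatter) in this series. The estimated value for compound 4 is 2000 nM with an expected range from 700 nM to 5500 nM on this read-out.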

Compound 4, half-maximal inhibitory concentration: > 5000 nM
Compound 4: no number, only a limit; the forecaster's own chance of this, stated with the estimate: 3%; at least 2.5-fold (0.39 log units) between middle value and limit.
By their numbers in this assay, from the lowest: compounds 2, 1 and 3 (each within the scatter of the next, the first and the last beyond it). At a limit, above all of these: compound 4.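

In this assay, earlier changes at this position stayed within the scatter or moved the number only modestly beyond it, whereas ethyl in place of hydrogen on the nitrogen, ethylamino to diethylamino, gives an at least 3.0-fold higher number from compound 3 to compound 4 (0.48 log units; beyond the scatter). Among the compounds shown here, the diethylamino group also stands clear of the other two compounds, with an at least 6.1-fold higher number from compound 1 to compound 4 (0.79 log units; beyond the scatter) and an at least 7.2-fold higher number from compound 2 to compound 4 (0.86 log units; beyond the scatter), so on this short set a second ethyl on the nitrogen is the one change that separates a compound from all the others. The value of compound 4 is a limit of the assay and not a number: the limit of > 5000 nM in this assay, at which 1 of the 4 values shown sits.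

From the compounds shown here alone, the true size of these steps remains open. Also open, going by these compounds, is where dimethylamino, propylamino or morpholine at this position would fall in this assay, and so whether the higher number goes with two chains on the nitrogen or with ethyl specifically.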